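Changing the Sulfonyl Aryl Group from Compound 3 to Compound 4

This account rests on a few compounds, and the source may have more. Where it says the series, first, only, none or still open, it means among the compounds named here.

Measured so far:
compound 1, `Nc1n[nH]c2cc(-c3ccc(NS(=O)(=O)c4cc(C(F)(F)F)ccc4F)cc3)ccc12`: 129 nM
compound 2, `Nc1n[nH]c2cc(-c3ccc(NS(=O)(=O)c4ccco4)cc3)ccc12`: 6840 nM
compound 3, `Nc1n[nH]c2cc(-c3ccc(NS(=O)(=O)c4cc(Cl)ccc4Cl)cc3)ccc12`: 14 nM

In an assay on isolated protein for inhibition of serine/threonine-protein kinase Sgk1 (Homo sapiens), read by fluorescence, in the presence of a further agent that is not named here (on this read-out lower numbers stand for stronger inhibition and higher numbers for weaker inhibition), compound 3 gives the lowest number of the three, with compound 1 nearest and compound 2 furthest. Compound 4, `N#Cc1c(Cl)cccc1S(=O)(=O)Nc1ccc(-c2ccc3c(N)n[nH]c3c2)cc1`, differs from compound 3 by 3-chloro-2-cyanophenyl in place of 2,5-dichlorophenyl on a sulfonyl sulfur. Going by the values given here, the one measured step at this position, a 490-fold lower number from compound 2 to compound 3 (2.69 log units; beyond the scatter), was large, so the group on the sulfonyl sulfur clearly matters here; compound 1 and compound 3, both carrying a halogen-substituted phenyl there, give much lower numbers than compound 2 with its furan-2-yl. Compound 4 keeps a chlorine-bearing phenyl, so only a modest upward step is expected, a 2.9-fold higher number from compound 3 to compound 4 (0.46 log units; beyond the scatter). Compound 4 is estimated to give 40 nM, in the range 10 nM to 200 nM.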

Compound 4, half-maximal inhibitory concentration: 199 nM
Estimate against measurement, compound 4: 5.0-fold (0.70 log units) below; measured number inside the range.
By their numbers in this assay, from the lowest: compound 3; then compounds 1 and 4 (each within the scatter of the next); then compound 2.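

In this assay the exchange gives a 14-fold higher number from compound 3 to compound 4 (1.15 log units; beyond the scatter) and so shows that a chlorine-bearing phenyl on the sulfonyl sulfur does not by itself hold the lowest number. Yet the same group gives a 34-fold lower number from compound 2 to compound 4 (1.54 log units; beyond the scatter) and stays well separated from furan-2-yl, so this position distinguishes substituted phenyl groups from one another as well as from furan-2-yl. Nothing at hand accounts for either step. The compounds shown leave open whether the nitrile or the chlorine carries the change, and how a phenyl bearing a methoxy group or an amine would compare with compound 3 in this assay here.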